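This account rests on a few compounds, and the source may have more. Where it says the series, first, only, none or still open, it means among the compounds named here.

Three compounds have been examined so far. Compound 1 `CC(=O)SCCC(CCCCC(=O)O)SC(C)=O` gives 9.22% in a functional assay on Bel-7402 cells (Homo sapiens) for inhibition, read by MTT assay, with a stated time of 24 h, tested at 10 ug/mL (on this read-out higher numbers stand for more inhibition of growth at the one concentration tested and lower numbers for less inhibition of growth), and compound 2 `O=C(CCCCC(S)CCS)Nc1ccc([N+](=O)[O-])cc1` gives 14.4% there, two values that lie within the usual scatter of each other. Compound 3 `CC(=O)SCCC(CCCCC(=O)Nc1ccccc1)SC(C)=O` has no single number to set beside them. It is reported as "not active" (no number reported) with no figure attached, so its distance from compound 1 and compound 2 cannot be stated as a step.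

Compound 4 `CC(=O)SCCC(CCCCC(=O)Nc1cccc(Cl)c1)SC(C)=O` keeps everything in compound 3 except for one change chloro in place of hydrogen on an aromatic carbon in which chloro takes the place of hydrogen on an aromatic carbon of a six-membered aromatic ring of carbon only, meta to a large group. Cut one bond further out, the same difference reads phenyl to 3-chlorophenyl.

For the measured compounds named here, no measured pair in this set shows what such a change does, so the data offer no direct guide to its size or direction. In this assay no step beyond the scatter is expected, and compound 4 may, like compound 3, be reported without a number. If a number is reported, it is expected to fall among the low figures seen so far, such as the 9.22% of compound 1 in the same test. The estimate for compound 4 is 10% with an expected range of 0% to 25% when a number is given.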

Compound 4, percent growth inhibition at one concentration: "not active" (no number reported)
Compound 4 has no reported number here; the estimate stays without a comparison.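

Compound 3 and compound 4 are both reported without a number in this assay, so no step can be read for the change from phenyl to 3-chlorophenyl. The compounds shown leave open whether chloro in place of hydrogen on this ring changes growth inhibition at all. No supporting evidence bears on this result.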